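Phenyl in Place of Trifluoromethyl on the Thiourea-Side Ring

A few compounds are considered here, and "the series" means these few. Any claim that something is new, unique, unknown or untested is made for them only; others in the source may bear on it.

Compound 1 `NC(=O)c1c(NC(=O)c2ccccc2Cl)sc2c1CCN(C(=S)Nc1ccccc1Br)C2`: 9090 nM
Compound 2 `NC(=O)c1c(NC(=O)c2ccccc2Cl)sc2c1CCN(C(=S)Nc1ccccc1C(F)(F)F)C2`: 10600 nM

In a functional assay on HL-60 cells (Homo sapiens) for antiproliferative activity, with a stated time of 24 h (on this read-out higher numbers stand for weaker inhibition and lower numbers for stronger inhibition), compound 2 gives 10600 nM, the highest of the two numbers, with compound 1 as its nearest neighbour within the scatter. Compound 3 `NC(=O)c1c(NC(=O)c2ccccc2Cl)sc2c1CCN(C(=S)Nc1ccccc1-c1ccccc1)C2` differs from compound 2 by phenyl in place of trifluoromethyl on an aromatic carbon. Going by the values given here, the only measured step, a 1.2-fold higher number from compound 1 to compound 2 (0.07 log units; within the scatter), also exchanges this group and stayed within the scatter. Among the compounds with values here, no measured step concerns phenyl itself, so compound 3 is expected to show no step beyond the scatter, a 1.1-fold lower number from compound 2 to compound 3 (0.03 log units; within the scatter). The estimated value of compound 3 in this assay is 10000 nM, within 4000 nM to 25000 nM.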

Compound 3, half-maximal inhibitory concentration: 34400 nM
The estimate for compound 3 lay 3.4-fold (0.54 log units) below the measured number; measured number outside the range, above it.
By their numbers in this assay, from the lowest: compounds 1 and 2 (each within the scatter of the next); then compound 3.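

In this assay, this place on an aromatic carbon, ortho to a large group, is not indifferent to every exchange: bromo and trifluoromethyl could not be told apart, but phenyl gives weaker inhibition than either (a 3.2-fold higher number from compound 2 to compound 3 (0.51 log units; beyond the scatter) and a 3.8-fold higher number from compound 1 to compound 3 (0.58 log units; beyond the scatter)). Both steps are beyond the scatter and modest, so the position tolerates a change of group only up to a point among these three compounds. Nothing available explains this result. On these data alone, it remains open whether an amine, a methoxy group or fluoro at this place would stay with compound 1 and compound 2 or go with compound 3.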